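An Amino Group Added to Compound 2: What to Expect

The source may report more compounds than this note shows. Statements on the series, on what has been measured and on what is new or still open speak of the compounds shown alone.

Two measured compounds share one core and differ only in how a side ring is attached. Compound 1 `ClCc1ccc(Cn2cnc3c(Cl)ncnc32)cc1` was tested in a functional assay on NCI-H522 cells (Homo sapiens) for cytotoxicity, read by sulforhodamine B assay, with a stated time of 48 h; on this read-out lower numbers stand for higher toxicity in this test and higher numbers for lower toxicity in this test. In this assay compound 1 gives > 100000 nM, which is a limit of the assay rather than a number. Compound 2 `ClCc1cccc(Cn2cnc3c(Cl)ncnc32)c1` in this assay gives > 100000 nM, again a limit and not a number. Compound 2 therefore sits at the edge of what this assay can resolve, matching the observation that (the limit of > 100000 nM in this assay, at which 2 of the 2 values shown sit). Compound 3 `Nc1nc(Cl)c2ncn(Cc3cccc(CCl)c3)c2n1` has not yet been measured. It differs from compound 2 by amino in place of hydrogen on an aromatic carbon. Going by the values given here, with no measured step available, the step is expected to be a step that the limit leaves unreadable from compound 2 to compound 3, no shift beyond the usual scatter in this assay. Compound 3 is therefore estimated at 120000 nM in this assay, within a range from 30000 nM to 400000 nM, and most likely reported again only as a limit.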

Compound 3, concentration lethal to 50% of the cells: 81300 nM
Estimate against measurement, compound 3: 1.5-fold (0.17 log units) above, and the stated range covers the measured number.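

Amino in place of hydrogen on an aromatic carbon, between two ring nitrogen atoms, gives in this assay an at least 1.2-fold lower number from compound 2 to compound 3 (0.08 log units; that floor lies within the scatter). Going by these compounds alone, compound 3 is the first compound here to give a number rather than a limit, so a change at this position can bring the read-out into the range the assay resolves. The real size of the step remains unknown because compound 2 gives no number to measure from: the limit of > 100000 nM in this assay, at which 2 of the 3 values shown sit.

From the compounds shown here alone, it remains open whether a dimethylamino group or a hydroxyl group in the same place would move the number further. Going by these compounds, it is also open whether the amino group would give a readable number on the core of compound 1, where the side ring is attached differently.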